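Cytotoxicity notes on two measured analogues and one pending

A few compounds are considered here, and "the series" means these few. Any claim that something is new, unique, unknown or untested is made for them only; others in the source may bear on it.

compound 1 `Cc1nn([C@H]2C[C@H](O)[C@@H](CO)S2)c(=O)nc1N` — > 200 ug/mL
compound 2 `Cc1nn([C@H]2C[C@H](O)[C@@H](CO)S2)c(=O)[nH]c1=S` — > 200 ug/mL

In a functional assay on E6SM cells (Homo sapiens) for cytotoxicity, read by microscopy (a lower number here means that less compound is tolerated, a higher number that more compound is tolerated), compound 1 gives > 200 ug/mL, which is a limit of the assay rather than a number. Compound 2 likewise reaches only a limit, > 200 ug/mL. Going by the values given here, both results sit at the limit of > 200 ug/mL in this assay, at which 2 of the 2 values shown sit, so no step between the measured compounds can be sized. Compound 3 `Cc1nn([C@H]2C[C@H](O)[C@@H](CO)S2)c(=O)nc1O` is not yet measured; it differs from compound 1 by hydroxy in place of amino on an aromatic carbon. No shift beyond the scatter is expected from this change, a step that the limit leaves unreadable from compound 1 to compound 3. Compound 3 is therefore estimated at 250 ug/mL, with a range from 150 ug/mL to 500 ug/mL, most probably again reported only as a limit.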

Compound 3, minimum cytotoxic concentration: > 200 ug/mL
Compound 3: no number, only a limit; the forecaster's own chance of this, stated with the estimate: 85%; the middle value is on the limit's open side.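

No step can be read between compound 1 and compound 3, because both results in this assay are limits rather than numbers: the limit of > 200 ug/mL in this assay, at which 3 of the 3 values shown sit. The compounds shown leave open at what concentration any of them becomes cytotoxic, and whether hydroxy in place of amino changes that concentration.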